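A few compounds are considered here, and "the series" means these few. Any claim that something is new, unique, unknown or untested is made for them only; others in the source may bear on it.

Measured in a physicochemical assay for solubility, in phosphate buffer, at pH 7.4; on this read-out higher numbers stand for higher solubility and lower numbers for lower solubility:
Compound 1 `CC(=O)N1CCC(c2cc3c(-c4ccc(=O)n(C(C)C)c4)ccnc3[nH]2)CC1`: 27000 nM
Compound 2 `CC(C)n1cc(-c2ccnc3[nH]c(C4CCN(CC(=O)N5CCCC5)CC4)cc23)ccc1=O`: 260000 nM
Compound 3 `COc1cc(F)ccc1-c1ccnc2[nH]c(C3CCN(CC(=O)N(C)C)CC3)cc12`: 38000 nM

Compound 3, at 38000 nM, lies within the scatter of compound 1. Compound 2 gives 260000 nM, and that number lies beyond the scatter of both. The next compound, compound 4 `CC(C)n1nc(-c2ccnc3[nH]c(C4CCN(CC(=O)N(C)C)CC4)cc23)ccc1=O`, keeps the rest of compound 3 and changes one group on an aromatic carbon: a group of 10 heavy atoms (7 carbon, 2 nitrogen, 1 oxygen; one six-membered aromatic ring with 2 hetero atoms) in place of a group of 9 heavy atoms (7 carbon, 1 oxygen, 1 fluorine; one six-membered aromatic ring of carbon only), on an aromatic carbon. The 4-fluoro-2-methoxyphenyl group leaves.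

Among the measured compounds shown here, the only measured step, a 9.6-fold higher number from compound 1 to compound 2 (0.98 log units; beyond the scatter), lies at the amine nitrogen in a ring and not at this aromatic carbon, so it bears on the change only indirectly. The closer guide is compound 2, which carries a closely similar group at the same place and gives 260000 nM, though it also differs from compound 4 at the amine nitrogen. Compound 1 goes against reading much from that group alone: it carries the same group as compound 2, yet compound 1 gives 27000 nM. A step upward beyond the scatter is therefore expected, though with wide uncertainty. The estimated change is a 3.9-fold higher number from compound 3 to compound 4 (0.60 log units; beyond the scatter). For compound 4 the expected value is 150000 nM, with an estimated range from 50000 nM to 400000 nM.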

Compound 4, solubility: 11000 nM
Compound 4: the middle estimate sits 14-fold (1.13 log units) above what was measured, and the stated range ends above it.
By their numbers in this assay, from the lowest: compound 4; then compounds 1 and 3 (each within the scatter of the next); then compound 2.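

In this assay, replacing the 4-fluoro-2-methoxyphenyl group on this aromatic carbon, opposite the ring nitrogen, with the group of 10 heavy atoms and one six-membered aromatic ring with 2 hetero atoms gives a 3.5-fold lower number from compound 3 to compound 4 (0.54 log units; beyond the scatter) and places compound 4 lowest of the four compounds. Among the compounds shown here, this is the first measured step at this aromatic carbon, and it shows that the number moves with the group here while the rest of compound 3 stays fixed; the earlier step, a 9.6-fold higher number from compound 1 to compound 2 (0.98 log units; beyond the scatter), lay at the amine nitrogen in a ring and could not show this. Nothing measured here explains the direction or size of the new step.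

On these data alone, a single pair now describes this position, so it remains open whether the same exchange would give a step of similar direction and size with acetyl or ((pyrrolidin-1-yl)carbonyl)methyl on the amine nitrogen. As far as these compounds go, it also remains open where an unsubstituted phenyl ring, a pyridine ring or a morpholine ring on this aromatic carbon would fall relative to the two groups compared here.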